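The source may hold more compounds than are shown below. What is called first, only, known or untested is meant among the compounds shown, and "the series" means these compounds.

In a functional assay on HCT-116 cells (Homo sapiens) for cytotoxicity, read by MTT assay, with a stated time of 2 days, tested at 10 uM (a higher number here means more inhibition at the concentration tested (going by the name of the read-out), a lower number less inhibition), the measured compounds stand as follows: compound 1 `Fc1ccc2nc(NCCCCN3CCN(c4cccc(Cl)c4Cl)CC3)nc(NCc3ccco3)c2c1` gives 97.1%; compound 2 `Clc1cccc(N2CCN(CCCCNc3nc(NCc4ccco4)c4ccccc4n3)CC2)c1Cl` gives 94.7%; compound 3 `CCN(CC)CCNc1nc(NCc2ccco2)c2cc(F)ccc2n1` gives 26.4%.

Compound 1 and compound 2 share one difference, (hydrogen in place of fluoro on an aromatic carbon), and in this assay this gave a number 2.4 percentage points lower from compound 1 to compound 2 (within the scatter). Compound 3 has the lowest number of the three in this assay, and its values against compound 1 and compound 2 are far apart; the difference between its core and that of compound 1 is not broken down here.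

Compound 4 `CCN(CC)CCNc1nc(NCc2ccco2)c2ccccc2n1` has not yet been measured in this assay. It differs from compound 3 by hydrogen in place of fluoro on an aromatic carbon, the same change seen between compound 1 and compound 2. Because that earlier change gave a number 2.4 percentage points lower from compound 1 to compound 2 (within the scatter), a step of about a number 0.4 percentage points lower from compound 3 to compound 4 (within the scatter) is expected from compound 3 to compound 4 in this assay. Compound 4 is therefore estimated at 26% in this assay, most likely between 10% and 45%.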

Compound 4, a percentage reported as inhibition, at one concentration (the size of the read-out at that concentration, not a potency): 50.3%
Compound 4: the middle estimate sits 24.3 percentage points below what was measured, outside the stated range (above it).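

In this assay, hydrogen in place of fluoro on an aromatic carbon did not behave as a step of fixed size: it gave a number 23.9 percentage points higher from compound 3 to compound 4 (beyond the scatter), and the two pairs disagree: the same change on two cores in this assay, a number 2.4 percentage points lower (within the scatter) from compound 1 to compound 2 and a number 23.9 percentage points higher (beyond the scatter) from compound 3 to compound 4, 26.3 percentage points apart, beyond the scatter of two such steps

In this series, then, the result of the change on one core did not carry over to the other, and the pair compound 1 and compound 2 was no reliable guide to the pair compound 3 and compound 4. These two pairs do not show why the steps differ, which part of the structures separating the two cores matters, or how the change would behave on any third core.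

The compounds shown leave open whether a chloro or methoxy group on that same aromatic carbon would follow hydrogen or fluoro on either core. They also leave open how the change would behave with a dimethylamine or a longer chain in place of the side chain of compound 3 and compound 4.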